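Cytotoxicity of a cyclobutylmethylamine to aniline swap

The compounds below may be only part of what the source reports. "The series", "measured", "known", "first", "only" and "open" are said of these compounds alone.

Of the compounds shown here, three of a shared core have been measured in an ADME assay on cells (Homo sapiens) for cytotoxicity, read by polymerase chain reaction, with a stated time of 3 days; a higher number here means that more compound is tolerated, a lower number that less compound is tolerated. Compound 1 `Nc1nc(Cl)c(-c2nc3ccc(Cl)cc3s2)c(N[C@@H]2C[C@H](CO)[C@@H](O)[C@H]2O)n1` gives 16000 nM in this assay. Compound 2 `Nc1ncc(-c2nc3ccccc3s2)c(N[C@@H]2C[C@H](CO)[C@@H](O)[C@H]2O)n1` reaches only the assay limit, > 25000 nM. Compound 3 `Cc1nc(NCC2CCC2)nc(N[C@@H]2C[C@H](CO)[C@@H](O)[C@H]2O)c1-c1nc2ccccc2s1` likewise returns only a limit in this assay, > 25000 nM, so no number is known for it and it stands at the limit of > 25000 nM in this assay, at which 2 of the 3 values shown sit, together with one other compound. No pair of these compounds differs in a single place, so no measured step exists among them.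

Compound 4 `Cc1nc(Nc2ccccc2)nc(N[C@@H]2C[C@H](CO)[C@@H](O)[C@H]2O)c1-c1nc2ccccc2s1` is not yet measured. It differs from compound 3 in one change: phenyl in place of cyclobutylmethyl on a nitrogen on an aromatic ring. The cyclobutylmethyl group leaves and a phenyl group enters on a nitrogen on an aromatic ring whose other neighbours are aromatic carbon. Among the measured compounds shown here, no measured step informs how this change acts in this assay, so compound 4 is expected to stay close to compound 3, with a step of a number no higher from compound 3 to compound 4 (the limit leaves the size open) that is not expected to exceed the scatter. Compound 4 is therefore estimated at 25000 nM in this assay, within a range from 10000 nM to 60000 nM, and most likely the assay again reports only a limit.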

Compound 4, half-maximal cytotoxic concentration: > 25000 nM
Compound 4: no number, only a limit (the forecaster's own chance of this, stated with the estimate: 60%); the middle value lies on the limit itself.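

In this assay compound 4 gives only the limit > 25000 nM and compound 3 also returns only a limit, so the step between them cannot be read. The compounds shown leave open whether phenyl in place of cyclobutylmethyl changes how much compound is tolerated.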